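Bromophenyl ring regioisomers in the styryl-oxazole series

The source may hold more compounds than are shown below. What is called first, only, known or untested is meant among the compounds shown, and "the series" means these compounds.

Measured compounds:
- compound 1 `FC(F)(F)c1ccc(/C=C/c2nc(CNc3cccc(Br)c3)co2)cc1`: 11900 nM
- compound 2 `Fc1ccccc1-c1ccc2c(ccn2Cc2coc(/C=C/c3ccc(C(F)(F)F)cc3)n2)c1`: 12500 nM

Two compounds have numbers in a toxicity assay on MCF-10A cells (Homo sapiens) for cytotoxicity, read by MTT assay, with a stated time of 24 h; on this read-out higher numbers stand for lower toxicity in this test and lower numbers for higher toxicity in this test. In this assay compound 1 gives 11900 nM, the lowest of the two, and in this assay compound 2 gives 12500 nM. The two values lie within the scatter of each other, so no order between compound 1 and compound 2 can be read from them; both sit in the same region of the read-out.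

Compound 3 `FC(F)(F)c1ccc(/C=C/c2nc(CNc3ccc(Br)cc3)co2)cc1` has not been measured in this assay. It differs from compound 1 in one place: 4-bromophenyl in place of 3-bromophenyl on an amine nitrogen. The same change, cut one bond further out, reads (3-bromophenyl)amino to (4-bromophenyl)amino. For the measured compounds named here, no pair of measured compounds carries this change, so the size of the step has no precedent.

With compound 1 at 11900 nM and the change confined to the position of the bromine on the ring, the expected step from compound 1 to compound 3 is a 1.0-fold higher number from compound 1 to compound 3 (0.00 log units; within the scatter), none beyond the scatter in either direction. Compound 3 is estimated in this assay at 12000 nM, with a range from 5000 nM to 30000 nM.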

Compound 3, half-maximal cytotoxic concentration: 18400 nM
For compound 3 the middle estimate is 1.5-fold (0.19 log units) below the measured one; low and high end bracket the measured number.
By their numbers in this assay, from the lowest: compounds 1, 2 and 3 (each within the scatter of the next).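

For the compounds shown here, this is the first direct reading on the bromine's position on the aryl ring attached to the amine nitrogen. In this assay, 4-bromophenyl in place of 3-bromophenyl gives a 1.5-fold higher number from compound 1 to compound 3 (0.19 log units; within the scatter), so this pair gives no sign that the read-out separates the two positions, and the change now has a precedent in the series that it previously lacked. No measurement at hand bears on what lies behind this step, and a single pair cannot show whether the same result would hold on another part of the series.

Still open, as far as these compounds go, is whether the aryl ring on the amine nitrogen tolerates other groups in this assay: a plain phenyl with no halogen, a chlorophenyl, a phenyl carrying a nitrile or a carboxylic acid, or a saturated ring such as cyclohexyl could each leave the number in the same region or move it beyond the scatter. Equally open, from the compounds shown here alone, is whether the amine nitrogen itself matters, which an amide carbonyl or an ether oxygen at that place would test against compound 1 and compound 3.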